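Swapping an Indole for a Pyrrolidinyl Phenyl Group

The compounds below may be only part of what the source reports. "The series", "measured", "known", "first", "only" and "open" are said of these compounds alone.

Of the compounds shown here, three that share one core have been measured in a physicochemical assay for lipophilicity; a lower number here means a more polar compound, a higher number a more lipophilic compound. Compound 3 `CN1CCN(CCCS(=O)(=O)c2ccc3nc(NC(=O)NC(=O)c4cc5c(ccn5C)cc4Cl)sc3c2)CC1` gives 2.8, the highest of the three numbers. Compound 1 `CN1CCN(CCCS(=O)(=O)c2ccc3nc(NC(=O)NC(=O)c4cc(-n5cccc5)ccc4Cl)sc3c2)CC1` gives 2.6, and compound 2 `CCOc1ccc(Cl)c(C(=O)NC(=O)Nc2nc3ccc(S(=O)(=O)CCCN4CCN(C)CC4)cc3s2)c1` gives 2.4. The change a number 0.20 log units higher from compound 1 to compound 3 (within the scatter) stays within the scatter, so compound 1 and compound 3 cannot be told apart, whereas a number 0.40 log units higher from compound 2 to compound 3 (beyond the scatter) is a modest step beyond it.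

Compound 4 `CN1CCN(CCCS(=O)(=O)c2ccc3nc(NC(=O)NC(=O)c4cc(N5CCCC5)ccc4Cl)sc3c2)CC1` has not yet been measured. It differs from compound 3 in one place: 2-chloro-5-(pyrrolidin-1-yl)phenyl in place of 5-chloro-1-methyl-1H-indol-6-yl on a carbonyl carbon. Going by the values given here, the group that enters has not appeared in any measured compound, so no direct step exists for it. The two steps in which the same indole group is exchanged for a differently substituted chlorophenyl group, a number 0.20 log units higher from compound 1 to compound 3 (within the scatter) and a number 0.40 log units higher from compound 2 to compound 3 (beyond the scatter), suggest that removing the indole tends to lower the number by a small amount, sometimes within the scatter and sometimes just beyond it. The step of a number 0.10 log units lower from compound 3 to compound 4 (within the scatter) is expected to fall within the scatter, in the downward direction. Compound 4 is estimated at 2.7, with a range from 2.3 to 3.1.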

Compound 4, distribution coefficient: 3.1
Estimate against measurement, compound 4: 0.40 log units below; low and high end bracket the measured number.
By their numbers in this assay, from the lowest: compounds 2, 1, 3 and 4 (each within the scatter of the next, the first and the last beyond it).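

In this assay, the earlier exchange on the aromatic carbon, ethoxy for 1H-pyrrol-1-yl, gave only a number 0.20 log units lower from compound 1 to compound 2 (within the scatter) and so left open whether this position could move the number at all, but pyrrolidin-1-yl now gives a number 0.50 log units higher from compound 1 to compound 4 (beyond the scatter) and a number 0.70 log units higher from compound 2 to compound 4 (beyond the scatter) as well. The first of these two steps exchanges an aromatic five-membered ring for a non-aromatic one, and that single exchange is enough to pass beyond the scatter, while the larger exchange of the indole for the 2-chloro-5-(pyrrolidin-1-yl)phenyl group gives a number 0.30 log units higher from compound 3 to compound 4 (within the scatter) and leaves these two compounds impossible to tell apart. Nothing shown here explains why the saturated ring stands apart from the pyrrole and ethoxy groups.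

Going by these compounds, it remains open whether the step belongs to this particular ring or to any saturated amine on that aromatic carbon, which a piperidin-1-yl, a morpholin-4-yl or an open-chain dimethylamino group could help to settle. Whether the same exchange gives a similar step on a different core, or with a group other than chlorine on the phenyl ring, also stays unanswered.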